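The source may report more compounds than this note shows. Statements on the series, on what has been measured and on what is new or still open speak of the compounds shown alone.

Measured so far in a functional assay on A2780cisR cells (Homo sapiens) for cytotoxicity; a lower number here means a stronger inhibitor, a higher number a weaker inhibitor:

- Compound 1 `C[C@@]1([C@H](OC(=O)c2ccc3ccccc3c2)C(N)=O)CO1`: 1350 nM
- Compound 2 `CCOC(=O)[C@@H](NC(=O)[C@@H](OC(=O)c1ccc(C)c2cc(OC)ccc12)[C@]1(C)CO1)C(C)C`: 560 nM

Of these two numbers, compound 2 has the lower, and its gap to compound 1 lies beyond the scatter. Compound 3 `CCOC(=O)CNC(=O)[C@@H](OC(=O)c1ccc(C)c2cc(OC)ccc12)[C@]1(C)CO1` has not yet been measured. It differs from compound 2 by a single change, hydrogen in place of isopropyl on a saturated chain carbon bound to an amide-type nitrogen and a carbonyl carbon. Among the measured compounds shown here, no measured pair shows this change, so its size in this assay remains uncertain. With compound 2 at 560 nM as the closest reference, only a small shift towards a higher number is expected, probably not beyond the scatter. The expected step is a 1.4-fold higher number from compound 2 to compound 3 (0.15 log units; within the scatter). For compound 3 the estimate is 800 nM, with an expected range from 300 nM to 2200 nM.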

Compound 3, half-maximal inhibitory concentration: 830 nM
For compound 3 the middle estimate is 1.0-fold (0.02 log units) below the measured one; low and high end bracket the measured number.
By their numbers in this assay, from the lowest: compounds 2, 3 and 1 (each within the scatter of the next, the first and the last beyond it).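

In this assay, among the compounds shown here, the exchange of isopropyl for hydrogen on a saturated chain carbon bound to an amide-type nitrogen and a carbonyl carbon comes to a 1.5-fold higher number from compound 2 to compound 3 (0.17 log units; within the scatter) and gives the first direct reading at this position. A step of this size cannot be told apart from the scatter, so in this pair the isopropyl makes no measurable difference to the value in this assay. No supporting data bear on this result.

The compounds shown leave open whether a larger group on this carbon, such as benzyl or a longer chain, or a carboxylic acid in place of the ethoxycarbonyl, would give a similar value. This single pair also cannot say whether the exchange would give as small a step on the core of compound 1.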